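The source may hold more compounds than are shown below. What is called first, only, known or untested is meant among the compounds shown, and "the series" means these compounds.

In a functional assay on Hs 683 cells (Homo sapiens) for cytotoxicity, read by MTT assay, with a stated time of 72 h (on this read-out lower numbers stand for stronger inhibition and higher numbers for weaker inhibition), compound 1 `COc1ccc2[nH]c(-c3ccc[nH]3)c(C3CC(=O)NC3=O)c2c1` gives 6000 nM and compound 3 `COc1ccc2[nH]c(-c3ccc[nH]3)cc2c1` gives 50000 nM, so compound 3 holds the higher of the two exact numbers and is the weaker inhibitor of this pair. Compound 2 `c1ccc2[nH]c(-n3cccn3)cc2c1` reads > 100000 nM, which is a limit of the assay and not a number.

The next change leads to compound 4 `COc1ccc2[nH]c(-n3cccn3)cc2c1`: 1H-pyrazol-1-yl in place of 1H-pyrrol-2-yl on an aromatic carbon. In words, 1H-pyrazol-1-yl takes the place of 1H-pyrrol-2-yl on an aromatic carbon. Going by the values given here, the one measured step is an 8.3-fold higher number from compound 1 to compound 3 (0.92 log units; beyond the scatter), where hydrogen replaces 2,5-dioxopyrrolidin-3-yl. That step involves a different group, so it shows how far one change can move the number here but does not predict the size of this one.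

The closest clue is compound 2, which also carries 1H-pyrazol-1-yl. A move towards a higher number is expected because compound 2 sits at the limit of > 100000 nM in this assay, at which 1 of the 3 values shown sits. With so little evidence, only a small rise is expected, not clearly beyond the usual scatter, and compound 4 could also reach the limit. The estimated change is a 1.6-fold higher number from compound 3 to compound 4 (0.20 log units; within the scatter). For compound 4 the expected value is 80000 nM, with an estimated range of 30000 nM to 200000 nM.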

Compound 4, half-maximal inhibitory concentration: 69000 nM
The estimate for compound 4 lay 1.2-fold (0.06 log units) above the measured number; the measured number falls inside the stated range.
By their numbers in this assay, from the lowest: compound 1; then compounds 3 and 4 (each within the scatter of the next). At a limit, above all of these: compound 2.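

In this assay, putting 1H-pyrazol-1-yl in place of 1H-pyrrol-2-yl on the aromatic carbon next to the ring nitrogen gives a 1.4-fold higher number from compound 3 to compound 4 (0.14 log units; within the scatter) and so leaves the two compounds indistinguishable. Going by these compounds alone, the group that leaves carries a hydrogen-bond donor and the group that enters carries none, yet this pair shows no difference beyond the scatter, which the earlier compounds could not show. Methoxy in place of hydrogen gives an at least 1.4-fold lower number from compound 2 to compound 4 (0.16 log units; that floor lies within the scatter) as only a floor, so the true size of that step stays unknown, and it starts from a limit of the assay and not a number: the limit of > 100000 nM in this assay, at which 1 of the 4 values shown sits.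

Within the data shown here, the larger step so far, an 8.3-fold higher number from compound 1 to compound 3 (0.92 log units; beyond the scatter) when hydrogen replaces 2,5-dioxopyrrolidin-3-yl, belongs to the pyrrole-bearing pair, and whether that group would matter as much alongside 1H-pyrazol-1-yl remains open. Among these compounds, it also remains open how an amine, a carboxylic acid or a longer chain would read at the place next to the ring nitrogen, where only two five-membered aromatic rings appear here.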